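Swapping the sulfonamide ring: from hydroxypiperidine to a spirocycle

This account rests on a few compounds, and the source may have more. Where it says the series, first, only, none or still open, it means among the compounds named here.

Three compounds sharing one core differ only in the ring attached to a sulfonyl sulfur. Compound 1 `CCCn1cc(S(=O)(=O)c2ccc(CNC(=O)N3Cc4ccncc4C3)cc2)cn1` gives 17 nM in an assay on isolated protein for inhibition of Nicotinamide phosphoribosyltransferase (Homo sapiens), read by mass spectrometry, with stated times of 15 min and 30 min; on this read-out lower numbers stand for stronger inhibition and higher numbers for weaker inhibition. Compound 2 `O=C(NCc1ccc(S(=O)(=O)N2CCOCC2)cc1)N1Cc2ccncc2C1` gives 71 nM, and compound 3 `O=C(NCc1ccc(S(=O)(=O)N2CCC[C@@H](O)C2)cc1)N1Cc2ccncc2C1` gives 28 nM. Compound 3 therefore sits between the other two: there is a 2.5-fold lower number from compound 2 to compound 3 (0.40 log units; beyond the scatter), while a 1.6-fold higher number from compound 1 to compound 3 (0.22 log units; within the scatter), so compound 3 and compound 1 cannot be told apart. The widest gap is a 4.2-fold higher number from compound 1 to compound 2 (0.62 log units; beyond the scatter).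

Compound 4 `O=C(NCc1ccc(S(=O)(=O)N2CC3(CCOCC3)C2)cc1)N1Cc2ccncc2C1` has not been measured. It differs from compound 3 in one place: a group of 9 heavy atoms (7 carbon, 1 nitrogen, 1 oxygen; one four-membered non-aromatic ring with 1 hetero atom, one six-membered non-aromatic ring with 1 hetero atom) in place of a group of 7 heavy atoms (5 carbon, 1 nitrogen, 1 oxygen; one six-membered non-aromatic ring with 1 hetero atom), on a sulfonyl sulfur. The three measured steps all concern the ring on this same sulfonyl sulfur and all stay modest, the largest being a 4.2-fold higher number from compound 1 to compound 2 (0.62 log units; beyond the scatter). A change of similar scale is expected here, most likely towards a somewhat higher number, though one that may fall within the scatter.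

Compound 4 is estimated at 50 nM, in a range from 18 nM to 140 nM, which would mean a 1.8-fold higher number from compound 3 to compound 4 (0.25 log units; within the scatter) as the expected step.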

Compound 4, half-maximal inhibitory concentration: 20 nM
For compound 4 the middle estimate is 2.5-fold (0.40 log units) above the measured one; the measured number falls inside the stated range.
By their numbers in this assay, from the lowest: compounds 1, 4 and 3 (each within the scatter of the next); then compound 2.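

In this assay the 3-hydroxypiperidin-1-yl on the sulfonyl sulfur, with its hydrogen-bond donor and defined stereocentre, can give way to a larger two-ring group with 0 hydrogen-bond donors and no stereocentre, with no readable change (a 1.4-fold lower number from compound 3 to compound 4 (0.15 log units; within the scatter)). The new group also holds the advantage over morpholin-4-yl (a 3.6-fold lower number from compound 2 to compound 4 (0.55 log units; beyond the scatter)) and cannot be told apart from the aromatic 1-propyl-1H-pyrazol-4-yl (a 1.2-fold higher number from compound 1 to compound 4 (0.07 log units; within the scatter)), so this position accepts rings of quite different shape among these compounds. No measurement at hand explains this tolerance.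

The compounds shown leave open whether the oxygen in the six-membered ring of compound 4 matters, which a version with an amine nitrogen or a plain carbon in its place would test. Also open, on these data alone, is how a longer chain or a carboxylic acid on that ring would fare.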